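The compounds below may be only part of what the source reports. "The series", "measured", "known", "first", "only" and "open" are said of these compounds alone.

In a functional assay on M21 cells (Homo sapiens) for antiproliferative activity, read by sulforhodamine B assay, with a stated time of 48 h (a higher number here means a weaker inhibitor, a lower number a stronger inhibitor), compound 1 `CCCN1CCN(c2ccc(S(=O)(=O)Oc3ccccc3C)cc2)C1=O` gives > 100000 nM, which is a limit of the assay and not a number. Compound 2 `CCCN1CCN(c2ccc(S(=O)(=O)Oc3ccccc3OC)cc2)C1=O` gives > 100000 nM, also a limit and not a number. So compound 2 has no readable potency, and the same holds for the only other compound measured: the limit of > 100000 nM in this assay, at which 2 of the 2 values shown sit. Among the compounds with values here, the one measured change, methoxy in place of methyl on an aromatic carbon, is a step that the two limits leave unreadable from compound 1 to compound 2. Compound 3 `CCCN1CCN(c2ccc(S(=O)(=O)Oc3cc(Cl)c(Cl)cc3Cl)cc2)C1=O` carries 2,4,5-trichlorophenyl in place of 2-methoxyphenyl on an oxygen. The measured step gives no size to carry over, so any expectation for this larger swap is weak. A modest move towards stronger inhibition in this assay is possible, but another limit is at least as likely. The expected change is an at least 2.0-fold lower number from compound 2 to compound 3 (0.30 log units; that floor lies within the scatter). Compound 3 is estimated at 50000 nM, with an expected range from 5000 nM to 100000 nM.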

Compound 3, half-maximal inhibitory concentration: 15000 nM
For compound 3 the middle estimate is 3.3-fold (0.52 log units) above the measured one, within the range that was stated.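

Within the data shown here, the swap at the oxygen whose other neighbour is the sulfonyl sulfur gives the only readable value so far in this assay, so the group held there can decide whether a number appears at all. 2,4,5-Trichlorophenyl in place of 2-methoxyphenyl gives an at least 6.6-fold lower number from compound 2 to compound 3 (0.82 log units; beyond the scatter), and in place of 2-methylphenyl it gives an at least 6.6-fold lower number from compound 1 to compound 3 (0.82 log units; beyond the scatter). Both steps start from a limit and not a number, so each gives only a floor and not a full size: the limit of > 100000 nM in this assay, at which 2 of the 3 values shown sit.

The chlorine atoms all enter in a single swap, so the compounds shown cannot tell whether one chlorine alone would give the same step, or which chlorine counts. On these data alone, how an amine or a carboxylic acid on this aromatic ring would read in this assay also stays open.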